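Chloro for Methoxy on an Amide Pair at the Limit

The source may report more compounds than this note shows. Statements on the series, on what has been measured and on what is new or still open speak of the compounds shown alone.

Compound 1, `O=C(Nc1cc(Sc2ncn[nH]2)c(O)c2ccccc12)c1cccc(Cl)c1`, in a functional assay on HCT-116 cells (Homo sapiens) for antiproliferative activity, read by MTT assay, with a stated time of 48 h; a lower number here means a stronger inhibitor, a higher number a weaker inhibitor: > 100000 nM, a limit of the assay.
Compound 2, `COc1ccc(C(=O)Nc2cc(Sc3ncn[nH]3)c(O)c3ccccc23)cc1`, in this assay: > 100000 nM, a limit of the assay.

Compound 2 stands at the limit of > 100000 nM in this assay, at which 2 of the 2 values shown sit, so its value is a limit and not a number. Within the data shown here, the only measured step, a step that the two limits leave unreadable from compound 1 to compound 2, therefore yields nothing that could be read. Compound 3, `O=C(Nc1cc(Sc2ncn[nH]2)c(O)c2ccccc12)c1ccc(Cl)cc1`, differs from compound 2 by chloro in place of methoxy on an aromatic carbon. Among the measured compounds shown here, no measured step bears on this exchange with a readable size, and both measured values sit at the same limit, so no step beyond the scatter can be expected in this assay in either direction. Compound 3 is therefore expected at 100000 nM, in a range from 30000 nM to 300000 nM. This estimate amounts to an expected step of a number no higher from compound 2 to compound 3 (the limit leaves the size open), most likely reported as a limit again.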

Compound 3, half-maximal inhibitory concentration: 43300 nM
Compound 3: the middle estimate sits 2.3-fold (0.36 log units) above what was measured; low and high end bracket the measured number.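

Compound 3 is the only one of the three to give a number rather than a limit in this assay, so this position, on an aromatic carbon para to a large group, can affect the read-out. Chloro in place of methoxy brings an at least 2.3-fold lower number from compound 2 to compound 3 (0.36 log units; beyond the scatter), and 4-chlorophenyl in place of 3-chlorophenyl brings an at least 2.3-fold lower number from compound 1 to compound 3 (0.36 log units; beyond the scatter), so both the identity of the group and where the chloro sits matter here. From the compounds shown here alone, the true sizes of both steps remain open, and the step between compound 1 and compound 2 cannot be read: the limit of > 100000 nM in this assay, at which 2 of the 3 values shown sit.

Whether chloro is specifically needed at this place stays open, since neither a fluoro, a methyl, a nitrile nor an amine on the same carbon is among the compounds shown. Going by these compounds, it is also open whether the exchange would hold with a different group in place of the hydroxyl on the shared core.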